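Swapping a Ring Amine for an Open Chain Amine

This account rests on a few compounds, and the source may have more. Where it says the series, first, only, none or still open, it means among the compounds named here.

Within the data shown here, only two compounds have been tested so far: compound 1 (`CCN(CC)CCNC(=O)CC(CC(=O)NC1Cc2ccccc2C1)c1ccccc1`) and compound 2 (`CN(C(=O)CC(CC(=O)NCCN1CCCC1)c1ccccc1)C1Cc2ccccc2C1`). In a functional assay on MGC-803 cells (Homo sapiens) for inhibition (a higher number here means a weaker inhibitor, a lower number a stronger inhibitor), compound 1 gives > 100000 nM as a limit of the assay and not a number. In this assay compound 2 gives > 100000 nM and this too is a limit. The evidence so far is therefore the limit of > 100000 nM in this assay, at which 2 of the 2 values shown sit, and compound 2 has no exact number to compare against.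

Compound 3 (`CCN(CC)CCNC(=O)CC(CC(=O)N(C)C1Cc2ccccc2C1)c1ccccc1`) differs from compound 2 by one change (diethylamino in place of pyrrolidin-1-yl on a saturated chain carbon, two bonds along the chain from an amide-type nitrogen) in which diethylamino replaces pyrrolidin-1-yl on a saturated chain carbon, two bonds along the chain from an amide-type nitrogen. Among the measured compounds shown here, no measured step guides this change, so in this assay no step beyond the scatter is expected (a number no higher from compound 2 to compound 3 (the limit leaves the size open)). For compound 3 the estimated value is 100000 nM with an expected range from 40000 nM to 200000 nM and another limit is quite likely.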

Compound 3, half-maximal inhibitory concentration: > 100000 nM
Compound 3: no number, only a limit; the forecaster's own chance of this, stated with the estimate: 75%; the middle value lies on the limit itself.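

The steps to compound 3 from compound 1 and from compound 2 cannot be read: in this assay all three compounds sit at a limit, not a number. Going by these compounds, whether diethylamino in place of pyrrolidin-1-yl, or methyl in place of hydrogen on the amide-type nitrogen, alters inhibition at all remains open.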